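The source may hold more compounds than are shown below. What is called first, only, known or untested is meant among the compounds shown, and "the series" means these compounds.

Values so far in a physicochemical assay for lipophilicity, read by HPLC, measured as chromatographic lipophilicity, at pH 7.4 (on this read-out lower numbers stand for lower lipophilicity and higher numbers for higher lipophilicity), are as follows.

- compound 1 `COc1cccc(NC(=O)c2nnn(Cc3ccncc3)c2N)c1` gives 1.4
- compound 2 `COc1cccc(NC(=O)c2nnn(CC3CCN(C(C)=O)CC3)c2N)c1` gives 1.2
- compound 3 `COc1cccc(NC(=O)c2nnn(Cc3ccc([S+](C)[O-])cc3)c2N)c1` gives 1.3

Compound 3 (1.3) lies within the scatter of both other compounds, so the three values do not separate. The steps that place it are a number 0.10 log units lower from compound 1 to compound 3 (within the scatter) and a number 0.10 log units higher from compound 2 to compound 3 (within the scatter), and the remaining step, a number 0.20 log units lower from compound 1 to compound 2 (within the scatter), also stays within the scatter.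

Next in the series is compound 4 `COc1cccc(NC(=O)c2nnn(Cc3ccc(C#N)cc3)c2N)c1`, which keeps the shared core. Its difference from compound 3 is a group of 2 heavy atoms (1 carbon, 1 nitrogen; no ring) in place of a group of 3 heavy atoms (1 carbon, 1 oxygen, 1 sulfur; no ring), on an aromatic carbon, so cyano replaces the group of 3 heavy atoms on an aromatic carbon, para to a large group.

All three measured steps change the group on the saturated chain carbon bound to an aromatic nitrogen, and none changes only the group on the aromatic carbon. They bear on this step only indirectly and set no size for it. A rise beyond the scatter in this assay is nevertheless expected, on the structural change alone, and this is the less secure part of the reasoning. The expected step is a number 0.90 log units higher from compound 3 to compound 4 (beyond the scatter), with a wide margin. For compound 4 the estimated value is 2.2, with an expected range from 1.7 to 2.7.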

Compound 4, distribution coefficient: 2.3
Compound 4: the middle estimate sits 0.10 log units below what was measured; measured number inside the range.
By their numbers in this assay, from the lowest: compounds 2, 3 and 1 (each within the scatter of the next); then compound 4.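

In this assay, the group on the aromatic carbon, para to a large group, proves able to move the number beyond the scatter: cyano in place of the sulfur-containing group of 3 heavy atoms gives a number 1.00 log units higher from compound 3 to compound 4 (beyond the scatter), although the two groups have the same counts of hydrogen-bond donors and acceptors and neither carries a net charge. Compound 4 also separates from the other two compounds, which did not separate from each other or from compound 3, with 4-cyanophenyl giving a number 1.10 log units higher from compound 2 to compound 4 (beyond the scatter) in place of 1-acetylpiperidin-4-yl and a number 0.90 log units higher from compound 1 to compound 4 (beyond the scatter) in place of pyridin-4-yl, both on the saturated chain carbon bound to an aromatic nitrogen. No supporting data are available to account for the size of any of these steps.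

With a single replacement at this aromatic carbon, the compounds shown do not tell whether the step belongs to the arrival of cyano or to the departure of the sulfur-containing group. A carboxylic acid, an amine or a simple methyl on the same carbon would show how far the number ranges at this position.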